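Methoxy in place of bromo: expectation for compound 4

The source may report more compounds than this note shows. Statements on the series, on what has been measured and on what is new or still open speak of the compounds shown alone.

Measured in a functional assay on MCF7 cells (Homo sapiens) for antiproliferative activity, read by MTT assay, with a stated time of 48 h; on this read-out lower numbers stand for stronger inhibition and higher numbers for weaker inhibition:
compound 1 `COc1ccc(/C=C/C(=O)Nc2nnc(-c3ccc(Br)cc3)s2)cc1`, 1.13 ug/mL
compound 2 `O=C(/C=C/c1ccccc1)Nc1nnc(-c2ccc(Br)cc2)s1`, 1.5 ug/mL
compound 3 `O=C(/C=C/c1ccc(F)cc1)Nc1nnc(-c2ccc(Br)cc2)s1`, 1.49 ug/mL

Compound 1 holds the lowest of the three numbers, but the step of a 1.3-fold higher number from compound 1 to compound 2 (0.12 log units; within the scatter) and the step of a 1.3-fold higher number from compound 1 to compound 3 (0.12 log units; within the scatter) both lie within the scatter, as does the step of a 1.0-fold lower number from compound 2 to compound 3 (0.00 log units; within the scatter); nothing separates the three compounds in this assay.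

Compound 4 `COc1ccc(/C=C/C(=O)Nc2nnc(-c3ccc(OC)cc3)s2)cc1` has not yet been measured. Relative to compound 1 it carries methoxy in place of bromo on an aromatic carbon. Among the measured compounds shown here, every measured step concerns the other six-membered aromatic ring, where methoxy, hydrogen and fluoro gave numbers within the scatter of one another; no measured step touches the bromo group. The data thus give no direct guide to this change, only the observation that swapping one aromatic substituent elsewhere in the series left the number in this assay within the scatter. The step from compound 1 to compound 4 is expected to be a 1.2-fold higher number from compound 1 to compound 4 (0.06 log units; within the scatter), with no direction preferred beyond the scatter. Compound 4 is therefore estimated at 1.3 ug/mL in this assay, in a range from 0.6 ug/mL to 3 ug/mL.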

Compound 4, half-maximal inhibitory concentration: 0.28 ug/mL
The estimate for compound 4 lay 4.6-fold (0.67 log units) above the measured number; measured number below the stated range.
By their numbers in this assay, from the lowest: compound 4; then compounds 1, 3 and 2 (each within the scatter of the next).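

Among the compounds shown here, the 4-bromophenyl to 4-methoxyphenyl change gives a 4.0-fold lower number from compound 1 to compound 4 (0.61 log units; beyond the scatter) in this assay, the only step beyond the scatter. This position, on an aromatic carbon para to a large group, therefore responds to a change of substituent, whereas methoxy, hydrogen and fluoro on the other aromatic ring gave numbers within the scatter of one another. This rests on one pair of compounds, and nothing available bears on why the number drops with methoxy in place of bromo.

Open, from the compounds shown here alone, is whether the same change gives a step of this size with hydrogen or fluoro on the other ring, as in compound 2 and compound 3. Also open, going by these compounds, is whether an amine, a hydroxyl or a longer alkoxy chain at this position gives a number nearer that of compound 4 or that of compound 1.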